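Three Side Chains on Sulfur, and a Fourth to Come

The compounds below may be only part of what the source reports. "The series", "measured", "known", "first", "only" and "open" are said of these compounds alone.

Compound 1 `CCC(O)CSc1nc(NCc2ccc(-c3ccccn3)cc2)c2[nH]nc(C(C)C)c2n1`: 273 nM
Compound 2 `CC(C)c1n[nH]c2c(NCc3ccc(-c4ccccn4)cc3)nc(SCC(N)CN)nc12`: 480 nM
Compound 3 `CCC(CO)Sc1nc(NCc2ccc(-c3ccccn3)cc2)c2[nH]nc(C(C)C)c2n1`: 255 nM

Three compounds share one core and differ only in the chain carried on the sulfur. In a functional assay on HT cells (Homo sapiens) for antiproliferative activity, read by fluorescence, with a stated time of 72 h (on this read-out lower numbers stand for stronger inhibition of growth and higher numbers for weaker inhibition of growth), compound 1 gives 273 nM, compound 2 gives 480 nM and compound 3 gives 255 nM. Compound 2 carries the number furthest from the other two, yet a 1.8-fold higher number from compound 1 to compound 2 (0.25 log units; within the scatter) and a 1.9-fold lower number from compound 2 to compound 3 (0.27 log units; within the scatter) both lie within the scatter, so the three chains are not told apart by this read-out.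

Compound 4 `CC(C)c1n[nH]c2c(NCc3ccc(-c4ccccn4)cc3)nc(SCCNC(N)=O)nc12` is the next member. It differs from compound 2 as follows: ureidomethyl in place of 1,2-diaminoethyl on a saturated chain carbon bound to a sulfur. The two steps that bear on this change, from compound 1 to compound 2 and from compound 2 to compound 3, each swap the chain on the sulfur and each stay within the scatter. Nothing in these numbers points in either direction, so for compound 4 the expected step is a 1.2-fold lower number from compound 2 to compound 4 (0.08 log units; within the scatter), that is, none beyond the scatter. Compound 4 is therefore estimated at 400 nM, with a range from 150 nM to 1100 nM.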

Compound 4, concentration for 50% growth inhibition: 240 nM
For compound 4 the middle estimate is 1.7-fold (0.22 log units) above the measured one; low and high end bracket the measured number.
By their numbers in this assay, from the lowest: compounds 4, 3, 1 and 2 (each within the scatter of the next).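

Compound 4 puts a ureido group, with its carbonyl, on the saturated chain carbon bound to the sulfur, where compound 2 carries 1,2-diaminoethyl, and even this change of group type stays within the scatter in this assay (a 2.0-fold lower number from compound 2 to compound 4 (0.30 log units; within the scatter)). The same holds against the two chains bearing a hydroxyl group (a 1.1-fold lower number from compound 3 to compound 4 (0.03 log units; within the scatter); a 1.1-fold lower number from compound 1 to compound 4 (0.06 log units; within the scatter)), so among these four compounds the diamino, hydroxyl and ureido chains on the sulfur are not told apart by this read-out. No measurement at hand goes beyond these growth-inhibition numbers to account for that sameness.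

Still open, on these data alone, is whether a carboxylic acid or a plain unsubstituted alkyl chain on the sulfur would stay within the same scatter. Also open, as far as these compounds go, is whether a longer chain ending in an amine or a ureido group would do so.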